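The source may hold more compounds than are shown below. What is called first, only, known or untested is meant among the compounds shown, and "the series" means these compounds.

Compound 1 `Fc1cccc(F)c1C#Cc1cncc2ccccc12` and compound 2 `Fc1cccc(F)c1C#Cc1cnc(Cl)c2ccccc12` differ in one place: chloro in place of hydrogen on an aromatic carbon. In a functional assay on LS174T cells (Homo sapiens) for inhibition, with a stated time of 4 days, tested at 10 uM (a lower number here means a weaker effect, a higher number a stronger effect of the compound at the concentration tested), compound 1 gives 87.9%, and compound 2 gives 94%, a step of a number 6.1 percentage points higher from compound 1 to compound 2 (within the scatter). Compound 3 `Fc1cccc(F)c1C#Cc1cnc2ccccc2c1` holds the same atoms as compound 1 joined differently; the difference between the two cores is not broken down here. In this assay compound 3 gives 90.4%, close to compound 1 and compound 2. Compound 4 `Fc1cccc(F)c1C#Cc1cnc2ccccc2c1Cl` is not yet measured. It arises from compound 3 by the same kind of change: chloro in place of hydrogen on an aromatic carbon. The surroundings are not identical, though: in compound 2 the chloro sits next to the ring nitrogen and para to a large group, while in compound 4 it sits ortho to a large group and opposite the ring nitrogen. Because the earlier step was a number 6.1 percentage points higher from compound 1 to compound 2 (within the scatter), compound 4 is expected to show a step of about a number 1.6 percentage points higher from compound 3 to compound 4 (within the scatter). The estimate for compound 4 is 92%, between 84% and 98%.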

Compound 4, a percentage reported as inhibition, at one concentration (the size of the read-out at that concentration, not a potency): 80.4%
Beside the measured number, compound 4's estimate is 11.6 percentage points above it, outside the stated range (below it).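

In this assay, chloro in place of hydrogen on an aromatic carbon gives a number 10 percentage points lower from compound 3 to compound 4 (within the scatter), and this step does not match the earlier one: the same change on two cores in this assay, a number 6.1 percentage points higher (within the scatter) from compound 1 to compound 2 and a number 10 percentage points lower (within the scatter) from compound 3 to compound 4, 16.1 percentage points apart, beyond the scatter of two such steps. Each step alone stays within the scatter, but together they show that the effect of this change did not carry over from the core of compound 1 to the core of compound 3. They do not show why: the core and the place of the chloro differ together between the two pairs, and two pairs give no rule for other cores.

The compounds shown leave open whether a different group, such as an amine or a methoxy, would follow the chloro on these two cores. They also leave open whether the same gap would appear with the chloro at other places on each core.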